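The source may report more compounds than this note shows. Statements on the series, on what has been measured and on what is new or still open speak of the compounds shown alone.

Measured in a functional assay on A549 cells (Homo sapiens) for antiproliferative activity, read by MTT assay, with a stated time of 72 h; a lower number here means a stronger inhibitor, a higher number a weaker inhibitor:
Compound 2, `CCN(CC)Cc1ccc(NC(=O)Nc2ccc3ncnc(Nc4cccc(C(F)(F)F)c4)c3c2)cc1`: 2070 nM.
Compound 1, `COC(=O)c1cccc(Nc2ncnc3ccc(NC(=O)Nc4ccc(CN5CCN(C)CC5)cc4)cc23)c1`: > 10000 nM, which is a limit of the assay and not a number.

Going by the values given here, compound 2 thus holds the only number in this assay; the other entry, (the limit of > 10000 nM in this assay, at which 1 of the 2 values shown sits), gives no measured value against which it can be set. Among the compounds with values here, no two measured compounds differ in a single place, so no measured step is available from which the effect of a change can be read.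

Compound 3, `CN1CCN(c2ccc(NC(=O)Nc3ccc4ncnc(Nc5cccc(C(F)(F)F)c5)c4c3)cc2)CC1`, differs from compound 2 by 4-methylpiperazin-1-yl in place of (diethylamino)methyl on an aromatic carbon. Within the data shown here, with no measured step to lean on, the expected change in this assay is judged to be small, within or close to the usual scatter, and if anything in the direction of a weaker inhibitor. Compound 3 is accordingly estimated at 3000 nM, with a range from 800 nM to 12000 nM. This estimate amounts to an expected step of a 1.4-fold higher number from compound 2 to compound 3 (0.16 log units; within the scatter).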

Compound 3, half-maximal inhibitory concentration: 2760 nM
Compound 3: the middle estimate sits 1.1-fold (0.04 log units) above what was measured; the range from low to high includes it.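

Going by these compounds alone, the change from (diethylamino)methyl to 4-methylpiperazin-1-yl gives the first step that can be read in this assay: a 1.3-fold higher number from compound 2 to compound 3 (0.12 log units; within the scatter). On this aromatic carbon, para to a large group, an open amine chain and a six-membered non-aromatic ring with 2 hetero atoms therefore give values that cannot be told apart. No measurement shown bears on why the two groups read alike.

Within the data shown here, compound 1 gives > 10000 nM, which is a limit of the assay and not a number, so no step involving compound 1 can be read. Still open, on these data alone, is whether a morpholine, a primary amine, a carboxylic acid or a longer chain at this position would move the number beyond the scatter.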